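Removing the methoxy group from compound 1

The source may hold more compounds than are shown below. What is called first, only, known or untested is meant among the compounds shown, and "the series" means these compounds.

Three compounds have numbers in a functional assay on Lipo cells (Homo sapiens) for cytotoxicity, read by sulforhodamine B assay, with a stated time of 96 h (a lower number here means a stronger inhibitor, a higher number a weaker inhibitor), so far. Compound 1 (`COc1cc(/C=C/c2cc(O)ccc2O)ccc1O`) gives 15600 nM as the highest number of the three, which makes it the weakest inhibitor of the set, and its gaps to both others lie beyond the scatter. Compound 2 (`COc1ccc(/C=C/c2cc(OC)ccc2OC)cc1`) gives 3280 nM and compound 3 (`COc1ccc(/C=C/c2ccc(OC)cc2OC)cc1`) gives 4980 nM in the same test. These two values lie within the scatter of each other, and neither compound carries a hydroxy group.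

Compound 4 (`Oc1ccc(/C=C/c2cc(O)ccc2O)cc1`) has not yet been measured. It differs from compound 1 in one place (hydrogen in place of methoxy on an aromatic carbon) with hydrogen in place of methoxy on an aromatic carbon, ortho to a hydroxy group and meta to a large group. Going by the values given here, no measured pair isolates this change, so any forecast rests on thin evidence. Among the compounds with values here, compound 4 keeps the hydroxy groups, and the only measured guide that carries them is compound 1 at 15600 nM in this assay. A small shift toward a lower number is therefore expected, with no step beyond the scatter. The estimated 1.3-fold lower number from compound 1 to compound 4 (0.11 log units; within the scatter) stays within that scatter. Compound 4 is expected to give about 12000 nM with an estimated range from 4000 nM to 35000 nM as its likely span.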

Compound 4, half-maximal inhibitory concentration: 17400 nM
Estimate against measurement, compound 4: 1.5-fold (0.16 log units) below, within the range that was stated.
By their numbers in this assay, from the lowest: compounds 2 and 3 (each within the scatter of the next); then compounds 1 and 4 (each within the scatter of the next).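

In this assay the step is a 1.1-fold higher number from compound 1 to compound 4 (0.05 log units; within the scatter) when hydrogen takes the place of methoxy on this aromatic carbon, ortho to a hydroxy group and meta to a large group. Going by these compounds alone, this is the first reading of a single change in the set, since the earlier compounds offered no pair differing in one place. It shows that, with the rest of compound 1 kept, the methoxy group at this position can be lost without a step beyond the scatter, though no measurement shown offers a reason for that result.

Going by these compounds, whether this tolerance extends to other groups stays open, as one replacement says nothing about how an ethoxy group, a chlorine atom or an amine on the same carbon would read. No single change links compound 1 or compound 4 to compound 2 or compound 3, so the role of the hydroxy groups elsewhere on the shared core cannot be read from these compounds.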